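From Ethylsulfanyl to Ethoxy on a Thiazole-Type Core

The source may hold more compounds than are shown below. What is called first, only, known or untested is meant among the compounds shown, and "the series" means these compounds.

Of the compounds shown here, three have been measured in a functional assay on MV4-11 cells (Homo sapiens) for inhibition, read by resazurin assay, with a stated time of 72 h; on this read-out higher numbers stand for weaker inhibition of growth and lower numbers for stronger inhibition of growth. Compound 1 `COc1ccc(Nc2nccc(-c3cn(C4CCCC4)c4ccccc34)n2)c(OC)c1` gives 1740 nM. Compound 3 `COc1ccc(Nc2nccc(-c3sc(OC)nc3C)n2)c(OC)c1` gives 1400 nM. Compound 2 `CCSc1nc(C)c(-c2ccnc(Nc3ccc(OC)cc3OC)n2)s1` gives 32400 nM, the highest of the three numbers; its nearest neighbour is compound 1 and its furthest is compound 3, both beyond the scatter.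

The step to compound 4 `CCOc1nc(C)c(-c2ccnc(Nc3ccc(OC)cc3OC)n2)s1` changes compound 2 at a single position: ethoxy in place of ethylsulfanyl on an aromatic carbon. Going by the values given here, only one measured step bears on it. Replacing the ethylsulfanyl group with methoxy on the same aromatic carbon gave a 23-fold lower number from compound 2 to compound 3 (1.36 log units; beyond the scatter), a large drop in the number. Ethoxy shares the oxygen link of methoxy and the two-carbon chain of ethylsulfanyl, so a sizeable fall from compound 2 is expected, though perhaps not the full extent seen with compound 3.

Compound 4 is therefore expected to reach about 3000 nM in this assay, with a likely range from 800 nM to 12000 nM. This estimate corresponds to an expected 11-fold lower number from compound 2 to compound 4 (1.03 log units; beyond the scatter).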

Compound 4, concentration for 50% growth inhibition: 3890 nM
Compound 4: middle estimate off by 1.3-fold (0.11 log units), on the low side; low and high end bracket the measured number.
By their numbers in this assay, from the lowest: compounds 3 and 1 (each within the scatter of the next); then compound 4; then compound 2.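

In this assay, placing ethoxy instead of ethylsulfanyl on the aromatic carbon next to the ring nitrogen and next to the ring sulfur gives an 8.3-fold lower number from compound 2 to compound 4 (0.92 log units; beyond the scatter) and shows that the fall seen with methoxy is not limited to that one group. The two oxygen-linked groups can now be compared directly: the added methyl on the saturated chain carbon gives a 2.8-fold higher number from compound 3 to compound 4 (0.44 log units; beyond the scatter) and so takes back part of the fall, though compound 4 remains well below compound 2. Nothing shown here gives a reason for either step.

As far as these compounds go, whether a longer chain such as propoxy would raise the number further remains open. So does how an amine on the same carbon would compare with these oxygen-linked groups.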